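A few compounds are considered here, and "the series" means these few. Any claim that something is new, unique, unknown or untested is made for them only; others in the source may bear on it.

In a functional assay on HEL cells (Homo sapiens) (on this read-out higher numbers stand for lower toxicity in this test and lower numbers for higher toxicity in this test), compound 1 `CCCCCCCCCc1cc2cn(COCCO)c(=O)nc2o1` is the starting point. Compound 1 gives only a limit, >= 100000 nM. Compound 2 `CCCCCC#Cc1cc2cn(COCCO)c(=O)nc2o1` likewise gives a limit, > 50000 nM. Compound 3 `CCCCCCCCCCc1cc2cn(COCCO)c(O)nc-2n1` gives 32000 nM. Compound 4 `CCCCCCCCc1cc2cn(COCCO)c(=O)nc2o1` has not yet been measured in this assay. It differs from compound 1 by hydrogen in place of methyl on a saturated chain carbon, eight bonds along the chain from an aromatic carbon. No step between two measured compounds is shown, so the effect of this change cannot be read from the numbers; so small a change is expected to move this assay by nothing beyond the scatter. Near the limit of compound 1, compound 4 is expected to give about 100000 nM, with a range from 30000 nM to 300000 nM. The step of a number no higher from compound 1 to compound 4 (the limit leaves the size open) that this estimate means is expected to be none beyond the scatter.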

Compound 4, half-maximal cytotoxic concentration: > 200000 nM
Compound 4 ended at the assay's limit; the forecaster's own chance of this, stated with the estimate: 80%; at least 2.0-fold (0.30 log units) between middle value and limit.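

Among these compounds, compound 1 and compound 4 both gave only limits in this assay, not numbers, so no step between them can be read. The compounds shown leave open whether hydrogen in place of methyl at this place changes toxicity at all.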